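Methoxy for chloro on the imine-side aryl of compound 1

The compounds below may be only part of what the source reports. "The series", "measured", "known", "first", "only" and "open" are said of these compounds alone.

In a functional assay on Caco-2 cells (Homo sapiens) for antiproliferative activity, read by MTT assay, with a stated time of 24 h (on this read-out lower numbers stand for stronger inhibition and higher numbers for weaker inhibition), compound 1 (`Fc1ccc(C2CC(c3ccc(Cl)cc3)=NN2c2ccc(-c3ccccc3)nn2)cc1`) returns only a limit, > 100000 nM. Compound 3 (`COc1ccc(C2CC(c3ccc(Cl)cc3)=NN2c2ccc(-c3ccccc3)nn2)c(OC)c1`) likewise sits at a limit, > 100000 nM; this is the limit at which two of the three values rest (the limit of > 100000 nM in this assay, at which 2 of the 3 values shown sit). Among the compounds with values here, compound 2 (`FC(F)(F)c1ccc(C2CC(c3ccc(Cl)cc3)=NN2c2ccc(-c3ccccc3)nn2)cc1`) is the one compound with a number, giving 10000 nM. The step of an at least 10-fold lower number from compound 1 to compound 2 (1.00 log units; beyond the scatter) and the step of an at least 10-fold higher number from compound 2 to compound 3 (1.00 log units; beyond the scatter) both concern the aryl on the saturated ring carbon, and the step that the two limits leave unreadable from compound 1 to compound 3 cannot be sized. Compound 4 (`COc1ccc(C2=NN(c3ccc(-c4ccccc4)nn3)C(c3ccc(F)cc3)C2)cc1`) differs from compound 1 elsewhere: methoxy in place of chloro on an aromatic carbon, on an aromatic carbon of a six-membered aromatic ring of carbon only, para to a large group. Within the data shown here, no measured step changes this chloro, so the step to compound 4 has no direct precedent; the only move away from the limit came from trifluoromethyl on the other aryl, which compound 4 lacks. For compound 4 the expectation is therefore a number no higher from compound 1 to compound 4 (the limit leaves the size open), most likely another limit. Compound 4 is estimated at 100000 nM, within 20000 nM to 300000 nM.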

Compound 4, half-maximal inhibitory concentration: 18100 nM
The estimate for compound 4 lay 5.5-fold (0.74 log units) above the measured number, outside the stated range (below it).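

Methoxy in place of chloro, para to a large group, gives an at least 5.5-fold lower number from compound 1 to compound 4 (0.74 log units; beyond the scatter) in this assay. So far only the change to 4-(trifluoromethyl)phenyl on the saturated ring carbon had produced a number in this series; the present result shows that the aryl carrying chloro also responds, with the 4-fluorophenyl of compound 1 left in place. The step remains a lower bound on the true difference because compound 1 holds only a limit of the assay: the limit of > 100000 nM in this assay, at which 2 of the 4 values shown sit.

Chloro and methoxy are the only groups shown at this position, so whether an amine, a hydroxy group or a longer alkoxy chain there would go the same way remains open. Also open, going by these compounds, is what methoxy at this position would give together with trifluoromethyl on the other aryl.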